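Swapping the Butylsulfonyl for a Carbamate Hydrazide

The source may hold more compounds than are shown below. What is called first, only, known or untested is meant among the compounds shown, and "the series" means these compounds.

Compound 1, `CCCCNC(=O)[C@@H](NC(=O)c1cccc(Cn2ccnc2)c1)[C@@H](C)CC`: "not determined" (no result reported)
Compound 2, `CCCCS(=O)(=O)NC(=O)[C@@H](NC(=O)c1cccc(Cn2ccnc2)c1)[C@@H](C)CC`: 9900 nM
Compound 3, `CC[C@H](C)[C@H](NC(=O)c1cccc(Cn2ccnc2)c1)C(=O)NNS(=O)(=O)c1ccccc1`: > 100000 nM

All three compounds share the same core and differ only in the group attached to the amide-type nitrogen at the end of the chain. Within the data shown here, in an assay on HEK293 cells for displacement of a labelled ligand from Type-2 angiotensin II receptor (Homo sapiens) (a lower number here means a stronger inhibitor, a higher number a weaker inhibitor), compound 2 gives 9900 nM, which is the only single number among the three. For compound 3 the result > 100000 nM is a limit of the assay, not a measured number. For compound 1 no result was reported in this assay.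

Among the measured compounds shown here, only one measured step bears on the question: an at least 10-fold higher number from compound 2 to compound 3 (1.00 log units; beyond the scatter). There the butylsulfonyl on the amide-type nitrogen was replaced by (phenylsulfonyl)amino, and the binding fell to the limit (the limit of > 100000 nM in this assay, at which 1 of the 3 values shown sits).

Compound 4, `CC[C@H](C)[C@H](NC(=O)c1cccc(Cn2ccnc2)c1)C(=O)NNC(=O)OC(C)(C)C`, carries (tert-butoxycarbonyl)amino in place of butylsulfonyl on an amide-type nitrogen. As in the step to compound 3, the butylsulfonyl gives way to a group attached through an added amino nitrogen, so a similar weakening is expected, though the tert-butoxycarbonyl is not a sulfonyl and the size of the loss is uncertain.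

Compound 4 is therefore estimated at 40000 nM in this assay, with a likely range from 10000 nM to 150000 nM. The expected step is a 4.0-fold higher number from compound 2 to compound 4 (0.61 log units; beyond the scatter), and the assay may again report only a limit.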

Compound 4, inhibition constant: > 100000 nM
Compound 4 was reported as a limit; the forecaster's own chance of this, stated with the estimate: 40%; middle value at least 2.5-fold (0.39 log units) away from the limit.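

In this assay, putting (tert-butoxycarbonyl)amino in place of butylsulfonyl on the amide-type nitrogen gives an at least 10-fold higher number from compound 2 to compound 4 (1.00 log units; beyond the scatter). The earlier loss therefore does not depend on a phenylsulfonyl group: it also appears when the group on the added amino nitrogen is a tert-butoxycarbonyl, which contains no sulfur, although this pattern rests on compound 3 and compound 4 alone. The step between compound 3 and compound 4 cannot be read, and the two groups cannot be ranked, since both compounds end at the same limit: the limit of > 100000 nM in this assay, at which 2 of the 4 values shown sit.

Going by these compounds, what remains open is whether the added amino nitrogen alone accounts for the loss or whether the groups carried on it also contribute, and a plain amino group or an acetylamino group on the amide-type nitrogen could help to separate these two readings. On these data alone, it is also open whether binding can be improved from the level of compound 2 by keeping the direct sulfonyl link and changing its chain, for example to a hexylsulfonyl group.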